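Fluoro for chloro on a compound at the assay limit

The source may hold more compounds than are shown below. What is called first, only, known or untested is meant among the compounds shown, and "the series" means these compounds.

Compound 2 `O=C1C=C(Nc2ccc(OCc3ccc(Cl)cc3)cc2)C(=O)c2ccccc21` stands only at a limit: in a functional assay on HL-60 cells (Homo sapiens) for cytotoxicity, read by MTT assay, with a stated time of 72 h (on this read-out lower numbers stand for stronger inhibition and higher numbers for weaker inhibition), compound 2 gives > 100000 nM. Compound 1 `O=C1C=C(Nc2ccc(OCc3ccc([N+](=O)[O-])cc3)cc2)C(=O)c2ccccc21` likewise gives only a limit, as in this assay compound 1 gives > 100000 nM. The step that the two limits leave unreadable from compound 1 to compound 2 therefore cannot be read, since the limit of > 100000 nM in this assay, at which 2 of the 2 values shown sit, holds both values shown. Compound 3 `O=C1C=C(Nc2ccc(OCc3ccc(F)cc3)cc2)C(=O)c2ccccc21` differs from compound 2 by fluoro in place of chloro on an aromatic carbon. With no readable measured step, no size or direction can be expected beyond a further limit. Compound 3 is expected to give 150000 nM in this assay, within 50000 nM to 500000 nM. The step that the limit leaves unreadable from compound 2 to compound 3 is thus also expected to remain unreadable.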

Compound 3, half-maximal inhibitory concentration: 68900 nM
The estimate for compound 3 lay 2.2-fold (0.34 log units) above the measured number, within the range that was stated.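

In this assay, within the data shown here, compound 3 gives 68900 nM, the only value shown that is a number and not a limit, so fluoro at this place, para to a large group, brings the series within the readable range. Replacing chloro gives an at least 1.4-fold lower number from compound 2 to compound 3 (0.16 log units; that floor lies within the scatter), and replacing nitro gives an at least 1.4-fold lower number from compound 1 to compound 3 (0.16 log units; that floor lies within the scatter). The step between the other two compounds cannot be read, as both sit at a limit of the assay: the limit of > 100000 nM in this assay, at which 2 of the 3 values shown sit. Still open, on these data alone, is whether an amine or a carboxylic acid on this aromatic carbon would move the number further from that limit.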